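The source may report more compounds than this note shows. Statements on the series, on what has been measured and on what is new or still open speak of the compounds shown alone.

Measured so far:
compound 1, `O=S(=O)(NCCCNCc1ccc(C(F)(F)F)cc1)c1cc(C(F)(F)F)cc(C(F)(F)F)c1` — 2000 nM
compound 2, `O=S(=O)(NCCCNCc1cccc(Cl)c1)c1cc(C(F)(F)F)cc(C(F)(F)F)c1` — 5900 nM

In a functional assay on ASPC1 cells (Homo sapiens) for inhibition, read by MTT assay, with a stated time of 72 h (on this read-out lower numbers stand for stronger inhibition of growth and higher numbers for weaker inhibition of growth), compound 1 gives 2000 nM and compound 2 gives 5900 nM. Among the compounds with values here, compound 2 therefore stands at the higher of the two numbers, with compound 1 the only neighbour, by a 3.0-fold higher number from compound 1 to compound 2 (0.47 log units; beyond the scatter). Compound 3, `O=S(=O)(NCCCNCc1ccc(Cl)cc1)c1cc(C(F)(F)F)cc(C(F)(F)F)c1`, differs from compound 2 by 4-chlorophenyl in place of 3-chlorophenyl on a saturated chain carbon bound to an amine nitrogen. Within the data shown here, the one measured step works at the same place on the molecule, the saturated chain carbon bound to an amine nitrogen, and it shows that the group there matters; it does not directly compare the two chlorophenyl isomers. What it does show is that compound 1, carrying 4-(trifluoromethyl)phenyl, gave the lower number, so a modest move toward lower numbers in this assay is expected for compound 3, though with wide uncertainty. For compound 3 the estimate is 3500 nM, in the range 1500 nM to 8000 nM, which would mean a 1.7-fold lower number from compound 2 to compound 3 (0.23 log units; within the scatter).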

Compound 3, concentration for 50% growth inhibition: 3000 nM
Compound 3: middle estimate off by 1.2-fold (0.07 log units), on the high side; the measured number falls inside the stated range.
By their numbers in this assay, from the lowest: compounds 1, 3 and 2 (each within the scatter of the next, the first and the last beyond it).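

In this assay, the shift from 3-chlorophenyl to 4-chlorophenyl gives a 2.0-fold lower number from compound 2 to compound 3 (0.29 log units; within the scatter), so the two chlorophenyl isomers cannot be told apart on this saturated chain carbon bound to an amine nitrogen. Chloro in place of trifluoromethyl on an aromatic carbon gives a 1.5-fold higher number from compound 1 to compound 3 (0.18 log units; within the scatter), so that exchange cannot be resolved either, and neither change alone reproduces a 3.0-fold higher number from compound 1 to compound 2 (0.47 log units; beyond the scatter), the earlier step that lies beyond the scatter. Nothing available explains these numbers.

The compounds shown leave open whether an unsubstituted phenyl, or a methoxy or nitrile on that ring, would give a number outside this narrow band. They also leave open how an amide in place of the amine, or a longer chain, would read in this assay.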